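Chloro to Phenyl: Weighing Up Compound 4's Cytotoxicity

A few compounds are considered here, and "the series" means these few. Any claim that something is new, unique, unknown or untested is made for them only; others in the source may bear on it.

Compound 1 `COC(=O)c1ccc(NCc2cncn2Cc2ccc(Cl)cc2)cc1-c1ccccc1` gives 25000 nM in a toxicity assay on NIH3T3 cells (Mus musculus) for cytotoxicity, read by resazurin assay; a higher number here means that more compound is needed for the effect, a lower number that less compound is needed.
Compound 2 `CNC(=O)c1ccc(NCc2cncn2Cc2ccc(-c3ccccc3)cc2)cc1-c1ccccc1` gives only a limit, > 1000 nM.
Compound 3 `CCOC(=O)c1ccc(NCc2cncn2Cc2ccc(-c3ccccc3)cc2)cc1-c1ccccc1` gives only a limit, > 10000 nM.

Among these three readings, compound 1 carries the only outright number; the other two are limits of this assay. Going by the values given here, the single measured step, a step that the two limits leave unreadable from compound 2 to compound 3, cannot be sized for that reason, and it concerns a change on the carbonyl carbon rather than the aromatic position of interest here. Compound 4 `COC(=O)c1ccc(NCc2cncn2Cc2ccc(-c3ccccc3)cc2)cc1-c1ccccc1` is reached from compound 1 by phenyl in place of chloro on an aromatic carbon. Among the compounds with values here, no measured step touches this change, so nothing beyond the usual scatter is expected. Compound 4 is estimated at 25000 nM, between 8000 nM and 80000 nM. That estimate amounts to an expected no change at the digits printed from compound 1 to compound 4 (within the scatter).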

Compound 4, half-maximal effective concentration: > 1000 nM
Compound 4: only a limit was reported; the forecaster's own chance of this, stated with the estimate: 40%; the middle value does not contradict the limit.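

Compound 4 gives only a limit, and none of its steps from compound 1, compound 2 or compound 3 can be read. The compounds shown leave open whether phenyl in place of chloro shifts the reading of compound 1 in this assay at all.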